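Working notes: amino substitution on a shared core

A few compounds are considered here, and "the series" means these few. Any claim that something is new, unique, unknown or untested is made for them only; others in the source may bear on it.

Of the compounds shown here, three have been measured in a functional assay on SK-MEL-28 cells (Homo sapiens) for cytotoxicity, read by sulforhodamine B assay, with a stated time of 48 h; on this read-out higher numbers stand for weaker inhibition of growth and lower numbers for stronger inhibition of growth. Compound 1 `ClCc1ccc(Cn2cnc3c(Cl)ncnc32)cc1` gives 7940 nM in this assay. Compound 2 `Nc1nc(Cl)c2ncn(Cc3ccc(CCl)cc3)c2n1` differs from compound 1 by amino in place of hydrogen on an aromatic carbon; in this assay compound 2 gives 18200 nM, and the step of a 2.3-fold higher number from compound 1 to compound 2 (0.36 log units; beyond the scatter) is modest but beyond the scatter. Compound 3 `ClCc1ccccc1Cn1cnc2c(Cl)ncnc21` has the same atoms as compound 1 joined differently; the difference between the two cores is not broken down here. In this assay compound 3 gives 2290 nM, the lowest of the three numbers, with compound 1 and compound 2 both standing beyond the scatter above it.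

Compound 4 `Nc1nc(Cl)c2ncn(Cc3ccccc3CCl)c2n1` has not yet been measured. It differs from compound 3 by amino in place of hydrogen on an aromatic carbon. For the measured compounds named here, this is the same change as that from compound 1 to compound 2: the place on the core is described in identical words for both pairs, and it is the only occurrence of this change among the measured compounds, so its size is known from a single pair.

For compound 4 the step in this assay is expected to be a 2.3-fold higher number from compound 3 to compound 4 (0.36 log units; beyond the scatter), since the same change gave a 2.3-fold higher number from compound 1 to compound 2 (0.36 log units; beyond the scatter). Compound 4 is therefore estimated at 5300 nM in this assay. Going by the values given here, compound 4 is expected to fall in a range estimated from 2500 nM to 11000 nM, a wide range since only the single step of a 2.3-fold higher number from compound 1 to compound 2 (0.36 log units; beyond the scatter) supports the expectation.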

Compound 4, concentration for 50% growth inhibition: 4790 nM
Beside the measured number, compound 4's estimate is 1.1-fold (0.04 log units) above it; the range from low to high includes it.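

In this assay, amino in place of hydrogen on an aromatic carbon gives a 2.1-fold higher number from compound 3 to compound 4 (0.32 log units; beyond the scatter), a modest step that runs in the same direction as the earlier one on the core of compound 1. Set side by side, the two steps agree: the same change on two cores in this assay, a 2.3-fold higher number (0.36 log units; beyond the scatter) from compound 1 to compound 2 and a 2.1-fold higher number (0.32 log units; beyond the scatter) from compound 3 to compound 4, 1.1-fold (0.04 log units) apart, within the scatter of two such steps. This shows that, in this assay, the size of the change carried over from one core to the other, but it rests on two pairs only and does not show that the same size would hold on a further core or in another assay, nor does it say what lies behind the step.

The compounds shown leave open how other groups would compare at the same place on the ring, since only hydrogen and amino appear there; a methylamino group, a hydroxyl group or an amine on a longer chain would test whether the higher number goes with amino alone. Also open, on these data alone, is whether the step would keep its size with the chloro group on that ring exchanged for another group, such as methoxy or a morpholine ring, since the chloro group stays the same in all four compounds.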